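The compounds below may be only part of what the source reports. "The series", "measured", "known", "first", "only" and "open" are said of these compounds alone.

Three compounds built on one shared core, an acetamido-substituted phenyl glyoxamide, have been measured in an assay on mitochondria from liver for inhibition of Amine oxidase [flavin-containing] A (Rattus norvegicus), with a stated time of 60 min; a higher number here means a weaker inhibitor, a lower number a stronger inhibitor. Compound 1 `COC(=O)[C@H](CC(C)C)NC(=O)C(=O)c1ccccc1NC(C)=O` gives 72 nM in this assay, compound 2 `COC(=O)CCCCCNC(=O)C(=O)c1ccccc1NC(C)=O` gives 68 nM, and compound 3 `COC(=O)[C@H](C)NC(=O)c1ccc(NC(=O)C(=O)c2ccccc2NC(C)=O)cc1` gives 36 nM. The gaps between these three numbers all lie within the usual scatter of repeated measurements, so compound 3 sits alongside the other two rather than apart from them. Compound 4 `COC(=O)C[C@H](NC(=O)c1ccc(NC(=O)C(=O)c2ccccc2NC(C)=O)cc1)C(=O)OC` differs from compound 3 in one respect: methoxycarbonyl in place of hydrogen on a saturated chain carbon, two bonds along the chain from an amide-type nitrogen and a carbonyl carbon. This change lies at the far end of the molecule from the shared core, and nothing in the measured compounds speaks to its effect; the step from compound 3 to compound 4 is therefore expected to be small, about a 1.1-fold higher number from compound 3 to compound 4 (0.05 log units; within the scatter), with no clear direction beyond the scatter. Compound 4 is estimated to give 40 nM in this assay, within a range of 15 nM to 110 nM.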

Compound 4, half-maximal inhibitory concentration: 60 nM
Compound 4: the middle estimate sits 1.5-fold (0.18 log units) below what was measured, within the range that was stated.
By their numbers in this assay, from the lowest: compounds 3, 4, 2 and 1 (each within the scatter of the next).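

Putting methoxycarbonyl in place of hydrogen on this saturated chain carbon gives a 1.7-fold higher number from compound 3 to compound 4 (0.22 log units; within the scatter) in this assay. Compound 3 and compound 4 therefore cannot be told apart here, which shows that this position can carry methoxycarbonyl and keep a number in the same range. No measurement shown here offers an explanation for this result. Still open, as far as these compounds go, is how other groups on this carbon would read in this assay, such as a carboxylic acid, an amine or a longer chain.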